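The compounds below may be only part of what the source reports. "The series", "measured", "known", "first", "only" and "open" are said of these compounds alone.

Compound 2 `Nc1ncnc2c1c(Oc1cc(C(F)(F)F)ccn1)nn2C1CCC(O)C1` carries 3-hydroxycyclopentyl on an aromatic nitrogen, and in an ADME assay on microsomes from liver (Homo sapiens) for metabolic stability, read by LC-MS, using NADPH, with a stated time of 10 min, tested at 10 uM (on this read-out higher numbers stand for a longer-lived compound and lower numbers for a shorter-lived compound), compound 2 gives > 2.41 h, which is a limit of the assay and not a number. It thus stands at the limit of > 2.41 h in this assay, at which 1 of the 2 values shown sits. Compound 1 `Nc1ncnc2c1c(Oc1cc(C(F)(F)F)ccn1)nn2CC1CC1` carries cyclopropylmethyl there and gives 1.87 h. Within the data shown here, the one measured step that bears on the next change is an at least 1.2-fold higher number from compound 1 to compound 2 (0.11 log units; that floor lies within the scatter), so it offers a floor and no firm size. Compound 3 `Nc1ncnc2c1c(Oc1cc(C(F)(F)F)ccn1)nn2C1CCC1` has cyclobutyl in place of 3-hydroxycyclopentyl on an aromatic nitrogen. Among the measured compounds shown here, its new group, like the one in compound 1, is made of carbon only, so compound 3 is expected to read close to compound 1, which gives 1.87 h. In this assay, the expected change is a small fall, with no step beyond the scatter, although the limit leaves its true size open. The estimated step is an at least 1.2-fold lower number from compound 2 to compound 3 (0.10 log units; that floor lies within the scatter). For compound 3 the estimate is 1.9 h, with an expected range of 0.9 h to 3.8 h.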

Compound 3, half-life: 1.02 h
The estimate for compound 3 lay 1.9-fold (0.27 log units) above the measured number; low and high end bracket the measured number.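

In this assay, the change to cyclobutyl gives an at least 2.3-fold lower number from compound 2 to compound 3 (0.37 log units; beyond the scatter), so unlike the earlier floor, this step shows that the group on the aromatic nitrogen can move the half-life beyond the scatter. The two groups made of carbon only stay within the scatter of each other, with a 1.8-fold lower number from compound 1 to compound 3 (0.26 log units; within the scatter), so cyclobutyl and cyclopropylmethyl cannot be told apart on this read-out. Compound 2 remains a limit of the assay and not a number, so the full size of its gain over either carbon-only group stays unknown: the limit of > 2.41 h in this assay, at which 1 of the 3 values shown sits.

The compounds shown do not separate the hydroxy group from the five-membered ring, a question that plain cyclopentyl or 3-hydroxycyclobutyl would address. Going by these compounds, how an amine in place of the hydroxy group would read also stays open.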